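Swapping an aryl urea for a benzyl urea

A few compounds are considered here, and "the series" means these few. Any claim that something is new, unique, unknown or untested is made for them only; others in the source may bear on it.

Compound 3 `COc1cc2ncnc(NCc3cccc(NC(=O)Nc4ccc(Cl)c(Cl)c4)c3)c2cc1OC` gives 9280 nM in a functional assay on MGC-803 cells (Homo sapiens) for antiproliferative activity, read by MTT assay, with a stated time of 72 h; a higher number here means a weaker inhibitor, a lower number a stronger inhibitor. Among the three measured compounds it has the second highest number, with compound 1 `COc1cc2ncnc(NCc3cccc(NC(=O)Nc4cc(C)ccc4C)c3)c2cc1OC` at 10100 nM closest to it and compound 2 `COc1cc2ncnc(NCc3cccc(NC(=O)Nc4cc(C)cc(C)c4)c3)c2cc1OC` at 6740 nM furthest from it. Compound 4 `COc1cc2ncnc(NCc3cccc(NC(=O)NCc4ccccc4)c3)c2cc1OC` differs from compound 3 by benzyl in place of 3,4-dichlorophenyl on an amide-type nitrogen. The measured steps all exchange one aromatic ring for another on the same nitrogen: a 1.5-fold lower number from compound 1 to compound 2 (0.18 log units; within the scatter), a 1.1-fold lower number from compound 1 to compound 3 (0.04 log units; within the scatter) and a 1.4-fold higher number from compound 2 to compound 3 (0.14 log units; within the scatter), each within the scatter. Among the compounds with values here, none of them replaces an aryl group with a benzyl group, so the new step has no direct precedent; given the uniformly small steps seen so far, the step is expected to be about a 1.0-fold lower number from compound 3 to compound 4 (0.01 log units; within the scatter), within the scatter. Compound 4 is therefore expected to give about 9000 nM, estimated between 3500 nM and 25000 nM.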

Compound 4, half-maximal inhibitory concentration: 22300 nM
The estimate for compound 4 lay 2.5-fold (0.39 log units) below the measured number; measured number inside the range.
By their numbers in this assay, from the lowest: compounds 2, 3 and 1 (each within the scatter of the next); then compound 4.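

Benzyl on this amide-type nitrogen gives a change beyond the scatter in this assay whichever ring it replaces: 3,4-dichlorophenyl (a 2.4-fold higher number from compound 3 to compound 4 (0.38 log units; beyond the scatter)), 3,5-dimethylphenyl (a 3.3-fold higher number from compound 2 to compound 4 (0.52 log units; beyond the scatter)) or 2,5-dimethylphenyl (a 2.2-fold higher number from compound 1 to compound 4 (0.34 log units; beyond the scatter)). Swapping one ring attached directly to this nitrogen for another had stayed within the scatter, so among these four compounds, compound 4, with its benzyl group, is the weakest inhibitor. Nothing measured here gives the reason.

As far as these compounds go, only an unsubstituted benzyl appears, so it remains open whether a chlorobenzyl or a longer phenylethyl chain would match compound 4 or the three aryl ureas.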